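Pyridin-3-yl in place of 1,3-benzothiazol-2-yl: working notes

This account rests on a few compounds, and the source may have more. Where it says the series, first, only, none or still open, it means among the compounds named here.

Compound 1 `CC(C)(C)Sc1c(CC(C)(C)C(=O)O)n(Cc2ccc(Cl)cc2)c2ccc(OCc3ccc4cc(F)ccc4n3)cc12`: 2 nM
Compound 2 `CC(C)(C)Sc1c(CC(C)(C)C(=O)O)n(Cc2ccc(Cl)cc2)c2ccc(OCc3ccc4cc(F)c(F)cc4n3)cc12`: 7 nM
Compound 3 `CC(C)(C)Sc1c(CC(C)(C)C(=O)O)n(Cc2ccc(Cl)cc2)c2ccc(OCc3nc4ccccc4s3)cc12`: 3 nM

In a functional assay for inhibition, with Homo sapiens as the target (a higher number here means a weaker inhibitor, a lower number a stronger inhibitor), compound 3 stands within the scatter of compound 1, with a 1.5-fold higher number from compound 1 to compound 3 (0.18 log units; within the scatter). Compound 2 lies apart, with a 2.3-fold lower number from compound 2 to compound 3 (0.37 log units; beyond the scatter). Compound 4 `CC(C)(C)Sc1c(CC(C)(C)C(=O)O)n(Cc2ccc(Cl)cc2)c2ccc(OCc3cccnc3)cc12` is the next case, with pyridin-3-yl in place of 1,3-benzothiazol-2-yl on a saturated chain carbon bound to an oxygen on an aromatic ring. The nearest precedents are a 1.5-fold higher number from compound 1 to compound 3 (0.18 log units; within the scatter) and a 2.3-fold lower number from compound 2 to compound 3 (0.37 log units; beyond the scatter), both at this same place. Among the compounds with values here, the only other measured step is modest, a 3.5-fold higher number from compound 1 to compound 2 (0.54 log units; beyond the scatter). Within the data shown here, no measured step reaches a group as small as pyridin-3-yl, so the extrapolation is loose. In this assay a higher number is expected, larger than these steps: a 5.0-fold higher number from compound 3 to compound 4 (0.70 log units; beyond the scatter). For compound 4 the estimate is 15 nM, with an expected range of 4 nM to 70 nM.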

Compound 4, half-maximal inhibitory concentration: 8 nM
Compound 4: the middle estimate sits 1.9-fold (0.27 log units) above what was measured; low and high end bracket the measured number.
By their numbers in this assay, from the lowest: compounds 1 and 3 (each within the scatter of the next); then compounds 2 and 4 (each within the scatter of the next).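

In this assay, within the data shown here, pyridin-3-yl, the smallest group at this place so far and the only one with a single ring, costs only a modest step against the two-ring groups of compound 3 and compound 1 (a 2.7-fold higher number from compound 3 to compound 4 (0.43 log units; beyond the scatter); a 4.0-fold higher number from compound 1 to compound 4 (0.60 log units; beyond the scatter)). Size alone does not order this place, and compound 2 goes against such an order, since its larger group gives a step within the scatter (a 1.1-fold higher number from compound 2 to compound 4 (0.06 log units; within the scatter)). No measured evidence explains these steps.

On these data alone, whether phenyl, pyridin-2-yl or pyridin-4-yl at this place would match compound 4 remains open. So does whether the pyridine nitrogen matters at all.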